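The source may report more compounds than this note shows. Statements on the series, on what has been measured and on what is new or still open speak of the compounds shown alone.

Series notes. Compound 1 `N#Cc1c(NCc2ccccc2)sc2c1CCN(C(=O)c1ccn[nH]1)C2` and compound 2 `N#Cc1c(NCc2ccc(F)cc2)sc2c1CCN(C(=O)c1ccn[nH]1)C2` share a common core and differ by a fluoro in place of hydrogen on an aromatic carbon. In a functional assay on Chem-3 cells for antagonist activity at metabotropic glutamate receptor 1 (Homo sapiens), read by fluorescence and calcium flux (a lower number here means a stronger inhibitor, a higher number a weaker inhibitor), compound 1 gives 1090 nM and compound 2 gives 2030 nM; the step of a 1.9-fold higher number from compound 1 to compound 2 (0.27 log units; within the scatter) lies within the scatter, so the two numbers are not separated. Compound 2 thus carries the larger of the two numbers, while not distinguishable from compound 1. Compound 3 `N#Cc1c(NCc2ccc(F)cc2)sc2c1CCN(C(=O)c1ccccc1)C2` differs from compound 2 by phenyl in place of 1H-pyrazol-5-yl on a carbonyl carbon. For the measured compounds named here, no measured step bears on this change: the only step in hand is the fluoro exchange, which does not involve the carbonyl carbon or an exchange of one ring for another. There is no basis for expecting a change beyond the scatter in either direction, only uncertainty. The expected step is a 1.0-fold lower number from compound 2 to compound 3 (0.01 log units; within the scatter), essentially flat with a wide margin. Compound 3 is therefore estimated at 2000 nM, with a range from 500 nM to 8000 nM.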

Compound 3, half-maximal inhibitory concentration: 1810 nM
For compound 3 the middle estimate is 1.1-fold (0.04 log units) above the measured one, and the stated range covers the measured number.
By their numbers in this assay, from the lowest: compounds 1, 3 and 2 (each within the scatter of the next).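

At the carbonyl carbon, whose other neighbour is an amide-type nitrogen in a ring, phenyl in place of 1H-pyrazol-5-yl gives a 1.1-fold lower number from compound 2 to compound 3 (0.05 log units; within the scatter) in this assay and so does not separate the two numbers. The entering ring has 0 hydrogen-bond donors and 0 hydrogen-bond acceptors, so for this pair neither the donor nor the acceptor of 1H-pyrazol-5-yl is shown to be needed for the activity read here. No measured evidence bears on why the two acyl groups are not separated.

As far as these compounds go, whether an amine, a carboxylic acid or a longer chain on this carbonyl carbon would give a step beyond the scatter remains open. Also open, from the compounds shown here alone, is whether the fluoro exchange reads the same with benzoyl in place of (1H-pyrazol-5-yl)carbonyl.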